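The source may hold more compounds than are shown below. What is called first, only, known or untested is meant among the compounds shown, and "the series" means these compounds.

The study measured two compounds in an assay on NIH3T3 cells with Urotensin-2 receptor (Homo sapiens) as the target; a higher number here means that more compound is needed for the effect, a lower number that less compound is needed. Compound 1 `Cc1ccccc1C(=O)NC(CCN(C)C)c1ccc(Cl)cc1` gives 3550 nM in this assay, the highest of the two numbers. Compound 2 `CN(C)CC[C@H](NC(=O)c1ccc2ccccc2c1)c1ccc(Cl)cc1` gives 407 nM in this assay, a lower number, and the gap between compound 2 and compound 1 lies beyond the scatter. Compound 3 `Cc1ccccc1NC(=O)NC(CCN(C)C)c1ccc(Cl)cc1` has not yet been measured in this assay. It differs from compound 1 in one place: (2-methylphenyl)amino in place of 2-methylphenyl on a carbonyl carbon. The group that enters carries one hydrogen-bond donor, where the group that leaves carries none. Going by the values given here, no step between measured compounds touches this kind of change, so nothing in the data says how it plays out. The step of a 1.4-fold higher number from compound 1 to compound 3 (0.15 log units; within the scatter) is expected to be small, within the scatter or only slightly toward a higher number. Compound 3 is thus expected to give about 5000 nM in this assay, with a range from 1500 nM to 16000 nM.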

Compound 3, half-maximal effective concentration: 2290 nM
Beside the measured number, compound 3's estimate is 2.2-fold (0.34 log units) above it; the measured number falls inside the stated range.
By their numbers in this assay, from the lowest: compound 2; then compounds 3 and 1 (each within the scatter of the next).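

In this assay, the step with (2-methylphenyl)amino in place of 2-methylphenyl on a carbonyl carbon is a 1.6-fold lower number from compound 1 to compound 3 (0.19 log units; within the scatter). Going by these compounds alone, this is the first reading of any change at this place, and it shows that the added nitrogen, with its hydrogen-bond donor, leaves a number that cannot be told apart from that of compound 1. Nothing measured here bears on what lies behind this outcome.

The compounds shown leave open whether other links on the carbonyl carbon, such as an oxygen or a methylene group in place of the amino nitrogen, would also leave the number within the scatter. They also leave open whether a methyl group on that nitrogen, which would remove its hydrogen, would change the result.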